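Mirror-Image Change on a Triazole Chain Compound

This account rests on a few compounds, and the source may have more. Where it says the series, first, only, none or still open, it means among the compounds named here.

Compound 1 `CC[C@@H](CCn1cncn1)c1ccc(Cl)cc1` gives 55.1 ug/mL
Compound 2 `CCCC[C@@H](CCn1cncn1)c1ccccc1` gives 40.8 ug/mL
Compound 3 `CCCC[C@H](CCn1cncn1)c1ccc(Cl)cc1` gives 20.2 ug/mL

In an ADME assay on HEp-2 cells (Homo sapiens) for cytotoxicity, read by MTT assay, with a stated time of 3 days (on this read-out higher numbers stand for lower toxicity in this test and lower numbers for higher toxicity in this test), compound 3 gives the lowest of the three numbers, making it the most toxic of the set: compound 2 stands nearest, with a number beyond the scatter above it, and compound 1 stands furthest. Compound 4 `CCCC[C@@H](CCn1cncn1)c1ccc(Cl)cc1` has not yet been tested. the two compounds have the same atoms and bonds and differ only in configuration as drawn: 1 of 1 stereo elements differ; a stereocentre at a saturated chain carbon is drawn R in compound 3 and S in compound 4 Nothing else about the molecule changes. Among the measured compounds shown here, no step between measured compounds tells how such a change plays out, so the move is expected to give a 1.6-fold higher number from compound 3 to compound 4 (0.20 log units; within the scatter), a modest rise that may well fall within the usual scatter. For compound 4 the estimate in this assay is 32 ug/mL, with a range from 14 ug/mL to 75 ug/mL.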

Compound 4, half-maximal cytotoxic concentration: 17 ug/mL
Compound 4: the middle estimate sits 1.9-fold (0.27 log units) above what was measured; the measured number falls inside the stated range.
By their numbers in this assay, from the lowest: compounds 4 and 3 (each within the scatter of the next); then compounds 2 and 1 (each within the scatter of the next).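

In this assay, swapping the stereocentre at the saturated chain carbon gives a 1.2-fold lower number from compound 3 to compound 4 (0.07 log units; within the scatter), so the drawn configuration at this position makes no clear difference in this test. Compound 4 also links the series through single changes: chloro in place of hydrogen on an aromatic carbon gives a 2.4-fold lower number from compound 2 to compound 4 (0.38 log units; beyond the scatter), and ethyl in place of hydrogen on a saturated chain carbon, three bonds along the chain from an aromatic carbon, gives a 3.2-fold lower number from compound 1 to compound 4 (0.51 log units; beyond the scatter). The stereocentre comparison rests on a clean pair: the fact that compounds 3 and 4 differ only in the configuration as drawn

As far as these compounds go, whether the swap stays this small in compounds without the chloro remains open. So does the effect of a fluoro or methoxy group in place of chloro, or of a longer chain.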